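Fluoro to methyl on the compound 3 scaffold

A few compounds are considered here, and "the series" means these few. Any claim that something is new, unique, unknown or untested is made for them only; others in the source may bear on it.

compound 1 `O=C1/C(=C/c2cccc(Br)c2)Cc2ccccc21` gives 32400 nM
compound 2 `Cc1cccc(/C=C2\Cc3ccccc3C2=O)c1` gives 41300 nM
compound 3 `O=C1/C(=C/c2ccc(F)cc2)CCc2ccccc21` gives 33400 nM

All three values come from a functional assay on CCRF-CEM cells (Homo sapiens) for inhibition (on this read-out higher numbers stand for weaker inhibition and lower numbers for stronger inhibition), and lie within the scatter of each other. Compound 3 at 33400 nM therefore stands level with compound 1 and compound 2, and no order can be drawn among them.

Compound 4 `Cc1ccc(/C=C2\CCc3ccccc3C2=O)cc1` carries methyl in place of fluoro on an aromatic carbon on a six-membered aromatic ring of carbon only, para to a large group.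

Going by the values given here, one measured step bears on this change. Methyl in place of bromo gave a 1.3-fold higher number from compound 1 to compound 2 (0.11 log units; within the scatter) and so stayed inside the scatter. That step replaces bromo rather than fluoro and belongs to the core of compound 1, so it is only a loose guide. No step beyond the scatter is therefore expected in this assay and no direction can be called. The estimated step is a 1.1-fold higher number from compound 3 to compound 4 (0.06 log units; within the scatter) on this basis. Compound 4 is estimated at 38000 nM with an expected range from 22000 nM to 65000 nM in this read-out.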

Compound 4, half-maximal inhibitory concentration: 460000 nM
Compound 4: middle estimate off by 12-fold (1.08 log units), on the low side, outside the stated range (above it).
By their numbers in this assay, from the lowest: compounds 1, 3 and 2 (each within the scatter of the next); then compound 4.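

In this assay methyl in place of fluoro on an aromatic carbon, para to a large group, gives a 14-fold higher number from compound 3 to compound 4 (1.14 log units; beyond the scatter) and so clearly weakens inhibition on the core of compound 3. Methyl in place of bromo gave a 1.3-fold higher number from compound 1 to compound 2 (0.11 log units; within the scatter) on the core of compound 1, so that small step did not carry over to this change, which differs in the group leaving, its place and the core. Nothing measured here accounts for the large step.

Going by these compounds, it remains open whether the weaker inhibition follows from methyl entering or from fluoro leaving. Chloro, methoxy or an amine at this place on the core of compound 3 would help separate the two, and the same fluoro to methyl change on the core of compound 1 would test whether the step depends on the core.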